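The source may report more compounds than this note shows. Statements on the series, on what has been measured and on what is new or still open speak of the compounds shown alone.

Working notes on the series in an assay on CHO cells for displacement of a labelled ligand from prostaglandin E2 receptor EP1 subtype (Homo sapiens); a lower number here means a stronger inhibitor, a higher number a weaker inhibitor. Compound 1 `CCc1ccccc1N(CC(=O)NCc1ccccc1)S(=O)(=O)c1ccc(C)cc1` gives 63.1 nM in this assay. For the measured compounds named here, compound 2 `Cc1ccc(S(=O)(=O)N(CC(=O)NCc2ccc(Cl)cc2)c2cccnc2)cc1` differs from compound 1 in two places and no single step connects them, so their two values are only set side by side. In this assay compound 2 is recorded only as a limit, < 1000 nM, and no number fixes where it stands. That value sits at the limit of < 1000 nM in this assay, at which 1 of the 2 values shown sits. Compound 3 `Cc1ccc(S(=O)(=O)N(CC(=O)NCc2ccc(Cl)cc2)c2cccnc2C)cc1` differs from compound 2 by methyl in place of hydrogen on an aromatic carbon, next to the ring nitrogen and ortho to a large group. Going by the values given here, no measured step bears on this change, so the expectation rests on the shared core and the limit of compound 2 alone. The expected step is a step that the limit leaves unreadable from compound 2 to compound 3, a gain in this assay somewhat beyond the scatter, held with wide uncertainty. For compound 3 the estimate is 150 nM, expected to fall between 30 nM and 800 nM.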

Compound 3, inhibition constant: 200 nM
The estimate for compound 3 lay 1.3-fold (0.12 log units) below the measured number; measured number inside the range.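

No step can be read from compound 2 to compound 3 in this assay, because compound 2 is recorded only as a limit: the limit of < 1000 nM in this assay, at which 1 of the 3 values shown sits. The compounds shown leave open whether, and in which direction, going from pyridin-3-yl to 2-methylpyridin-3-yl changes the inhibition constant in this assay.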